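A few compounds are considered here, and "the series" means these few. Any claim that something is new, unique, unknown or untested is made for them only; others in the source may bear on it.

In a functional assay on A549 cells (Homo sapiens) for cytotoxicity, read by MTT assay, with a stated time of 48 h (a lower number here means a stronger inhibitor, a higher number a weaker inhibitor), compound 2 `C=C1C(=O)O[C@H]2CC3=C[C@H](C/C(C)=C/[C@@H](OC(=O)c4ccc(C(C)=O)cc4)[C@H]12)OC3=O` gives 2300 nM, and compound 3 `C=C1C(=O)O[C@H]2CC3=C[C@H](C/C(C)=C/[C@@H](OC(=O)c4ccc(-c5ccccc5)cc4)[C@H]12)OC3=O` gives 4600 nM. The step between them is a 2.0-fold higher number from compound 2 to compound 3 (0.30 log units; within the scatter), so these two numbers stand level and compound 2 has no real lead over compound 3. Compound 1 `C=C1C(=O)O[C@H]2CC3=C[C@H](C/C(C)=C/[C@@H](OC(=O)c4ccc(C(F)(F)F)cc4)[C@H]12)OC3=O` gives > 10000 nM, which is a limit of the assay and not a number. The other two steps start from that limit: an at least 4.3-fold lower number from compound 1 to compound 2 (0.63 log units; beyond the scatter) and an at least 2.1-fold lower number from compound 1 to compound 3 (0.33 log units; beyond the scatter). Both count only as minimum sizes, as the limit of > 10000 nM in this assay, at which 1 of the 3 values shown sits, marks.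

Compound 4 `C=C1C(=O)O[C@H]2CC3=C[C@H](C/C(C)=C/[C@@H](OC(=O)CCCCBr)[C@H]12)OC3=O` changes compound 2 as follows: 4-bromobutyl in place of 4-acetylphenyl on a carbonyl carbon. In words, 4-bromobutyl stands in place of 4-acetylphenyl on a carbonyl carbon. All three measured steps exchange a group on an aromatic carbon, and none removes the aromatic ring, so they bear on this change only indirectly. They show that the number can stay level, as in a 2.0-fold higher number from compound 2 to compound 3 (0.30 log units; within the scatter), or climb to the limit of compound 1, > 10000 nM. No direction can be drawn firmly from this, so no step beyond the scatter is the central expectation, with a wide margin and more room upward. The expected step is a 1.3-fold higher number from compound 2 to compound 4 (0.12 log units; within the scatter). For compound 4 the estimated value is 3000 nM, with an expected range of 1000 nM to 10000 nM.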

Compound 4, half-maximal inhibitory concentration: > 10000 nM
Compound 4: no number, only a limit (the forecaster's own chance of this, stated with the estimate: 15%); at least 3.3-fold (0.52 log units) between middle value and limit.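

The exchange of 4-acetylphenyl for 4-bromobutyl on a carbonyl carbon is the first one shown that removes the aromatic ring from this place, and it gives an at least 4.3-fold higher number from compound 2 to compound 4 (0.63 log units; beyond the scatter). In this assay compound 4 gives > 10000 nM, which is a limit of the assay and not a number, so that step counts only as a minimum size. Among the compounds shown, readable numbers occur only with an aromatic ring at this place, in compound 2 and compound 3, but compound 1 goes against any reading that the ring alone is enough, and the step between compound 1 and compound 4 cannot be read, as both sit at the same limit: the limit of > 10000 nM in this assay, at which 2 of the 4 values shown sit.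

Compound 4 loses the ring and gains bromine in one change, so the compounds shown do not separate the two. A plain butyl chain, a longer chain ending in bromine, or an amine in place of the bromine would each bear on this, and nothing shown says how any of them would read.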